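The source may report more compounds than this note shows. Statements on the series, on what has been measured and on what is new or still open speak of the compounds shown alone.

Measured compounds:
- compound 1, `O=C(/C=C/c1ccc(COc2ccccc2)cc1)NO`: "not determined" (no result reported)
- compound 2, `O=C(NO)c1ccc(COc2ccccc2)cc1`: "not determined" (no result reported)
- compound 3, `Nc1ccccc1NC(=O)c1ccc(CN2CCc3cc(Br)ccc32)cc1`: 7390 nM

Compound 1 has no single number in a functional assay on MGC-803 cells (Homo sapiens) for antiproliferative activity, read by CCK-8 assay, with a stated time of 72 h; on this read-out higher numbers stand for weaker inhibition and lower numbers for stronger inhibition; its entry reads "not determined" (no result reported), and compound 2 stands the same way with "not determined" (no result reported). For the measured compounds named here, the only number in this assay belongs to compound 3, which gives 7390 nM. So compound 1 cannot be placed on a scale against the others; nothing says whether it inhibits more or less strongly than compound 3.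

Compound 4, `Nc1cnccc1NC(=O)/C=C/c1ccc(COc2ccccc2)cc1`, differs from compound 1 at one spot: 3-aminopyridin-4-yl in place of hydroxy on an amide-type nitrogen. The change sits on the amide-type nitrogen whose other neighbour is the carbonyl carbon, so the rest of the molecule is kept.

Going by the values given here, no pair of measured compounds shows what this change does to the read-out. With compound 1 lacking a number, no size or direction of the step in this assay can be taken from the data shown; the expectation rests only on the single number of compound 3.

Compound 4 is estimated at 5000 nM, with a plausible range from 1000 nM to 25000 nM, an expectation anchored loosely on compound 3 and its 7390 nM.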

Compound 4, half-maximal inhibitory concentration: > 32000 nM
Compound 4: no number, only a limit (the forecaster's own chance of this, stated with the estimate: 15%); middle value at least 6.4-fold (0.80 log units) from the limit.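

In this assay compound 4 gives > 32000 nM, which is a limit of the assay and not a number. For the compounds shown here, with no single number for compound 1 either, no step between compound 1 and compound 4 can be read. As far as these compounds go, what remains open is how far, and in which direction, exchanging hydroxy for 3-aminopyridin-4-yl on the amide-type nitrogen shifts the read-out.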